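Swapping the amide substituent on a shared core: from benzyl to pyrazinyl

A few compounds are considered here, and "the series" means these few. Any claim that something is new, unique, unknown or untested is made for them only; others in the source may bear on it.

Measured compounds:
- compound 1, `O=C(NCc1ccccc1)c1c(O)c2cccnc2n(-c2ccccc2)c1=O`, gives 11.3% in a functional assay on the whole organism for inhibition, with Rattus norvegicus as the target, read by cytopathic effect and paw edema, at a dose of 100 mg/kg by the oral route; on this read-out lower numbers stand for less inhibition and higher numbers for more inhibition at the one dose given (going by the name of the read-out)
- compound 2, `O=C(Nc1ccncc1)c1c(O)c2cccnc2n(-c2ccccc2)c1=O`, gives 24.3%
- compound 3, `O=C(Nc1nccs1)c1c(O)c2cccnc2n(-c2ccccc2)c1=O`, gives 2.5%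

Among these three, compound 1 stands second highest; its gap to compound 3 is within the scatter, while compound 2 lies clearly above it. The three compounds share one core and differ only in the group carried on the amide-type nitrogen.

Compound 4, `O=C(Nc1cnccn1)c1c(O)c2cccnc2n(-c2ccccc2)c1=O`, is not yet measured. It differs from compound 1 as follows: pyrazin-2-yl in place of benzyl on an amide-type nitrogen.

Two measured steps start from compound 1 and each exchanges the benzyl group for a small heteroaromatic ring, as the step to compound 4 does. The first, a number 13 percentage points higher from compound 1 to compound 2 (beyond the scatter), raised the number; the second, a number 8.8 percentage points lower from compound 1 to compound 3 (within the scatter), stayed within the scatter. The comparison a number 21.8 percentage points lower from compound 2 to compound 3 (beyond the scatter) shows that the two heteroaromatic rings are themselves far apart. Since one such exchange helped and the other did not, only a small upward step, if any, is expected for compound 4: a number 3.7 percentage points higher from compound 1 to compound 4 (within the scatter). Compound 4 is therefore estimated at 15%, with a range from 2% to 30%.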

Compound 4, a percentage reported as inhibition, in the whole organism at one dose (the size of the read-out at that dose, not a potency): 21.2%
For compound 4 the middle estimate is 6.2 percentage points below the measured one, within the range that was stated.
By their numbers in this assay, from the lowest: compounds 3, 1, 4 and 2 (each within the scatter of the next, the first and the last beyond it).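

In this assay the exchange of benzyl for pyrazin-2-yl on the amide-type nitrogen gives a number 9.9 percentage points higher from compound 1 to compound 4 (within the scatter) and so cannot be told apart from leaving benzyl in place. The choice of ring at this position does matter: pyrazin-2-yl in place of 1,3-thiazol-2-yl gives a number 18.7 percentage points higher from compound 3 to compound 4 (beyond the scatter) while pyrazin-2-yl in place of pyridin-4-yl gives a number 3.1 percentage points lower from compound 2 to compound 4 (within the scatter) and so a second ring now groups with pyridin-4-yl and stands clear of 1,3-thiazol-2-yl. Nothing measured here explains why these rings separate in this way.

Still open, from the compounds shown here alone, is whether a ring carrying an amine or a carboxylic acid, or a longer chain in place of benzyl, would move the number clearly away from that of compound 1 in this assay at all. Each number also comes from a single oral dose, which leaves open how these compounds would compare at other doses.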